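Swapping the aryl group on the alkyne of compound 2

The compounds below may be only part of what the source reports. "The series", "measured", "known", "first", "only" and "open" are said of these compounds alone.

Among the measured compounds shown here, compound 2, `Cc1cccc(C#Cc2ccc3c(n2)CCN(C2CCCC2)C3=O)c1`, stands as the lower of the two numbers measured so far: in a functional assay on HEK293 cells for positive allosteric modulation of metabotropic glutamate receptor 5 (Homo sapiens), read by FLIPR and calcium flux (a higher number here means that more compound is needed for the effect, a lower number that less compound is needed), compound 2 gives 7.5 nM. The other measured compound is compound 1, `CC(C)NC(=O)c1ccc(C#Cc2ccccc2)nc1`, which in this assay gives 62 nM; the two compounds differ in several places, so only their two values are compared here. Compound 3, `O=C1c2ccc(C#Cc3ccccc3Cl)nc2CCN1C1CCCC1`, shares the core of compound 2 and differs in one place: 2-chlorophenyl in place of 3-methylphenyl on a triple-bonded carbon. For the measured compounds named here, no measured pair shows this particular change, so nothing in the data fixes its size or direction. The author expects a modest move toward a higher number, with the step from compound 2 to compound 3 estimated as a 3.3-fold higher number from compound 2 to compound 3 (0.52 log units; beyond the scatter), near the edge of the usual scatter. For compound 3 in this assay the estimate is 25 nM, with a range from 7 nM to 110 nM.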

Compound 3, half-maximal effective concentration: 393 nM
Compound 3: the middle estimate sits 16-fold (1.20 log units) below what was measured, and the stated range ends below it.
By their numbers in this assay, from the lowest: compound 2; then compound 1; then compound 3.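

Among the compounds shown here, this is the first measured change to the aryl group on the triple-bonded carbon, and in this assay it is a large one, with a 52-fold higher number from compound 2 to compound 3 (1.72 log units; beyond the scatter) for 2-chlorophenyl in place of 3-methylphenyl. The two groups match in heavy-atom count and in their lack of hydrogen-bond donors, acceptors and net charge, so these counts do not separate them, yet the number still moves far beyond the scatter. Nothing available bears on the reason for this rise.

The compounds shown leave open whether the step follows the chlorine itself or where the group sits on the ring, a question that 3-chlorophenyl or 2-methylphenyl on the same carbon would address. Going by these compounds, how an unsubstituted phenyl would compare on the core of compound 2 also remains open.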